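A few compounds are considered here, and "the series" means these few. Any claim that something is new, unique, unknown or untested is made for them only; others in the source may bear on it.

Compound 2, with structure `CC(=O)Nc1cc(-c2ccc(N(C)C(=O)c3c(F)cccc3Cl)c(OCC(C)C)c2)n(C(C)C)n1`, is the point of departure. Among the compounds with values here, in an ADME assay on a cell-free system (plasma, Homo sapiens) (a lower number here means a smaller unbound share, a higher number a larger unbound share of the compound), compound 2 gives 0.003, the lowest of the two numbers measured so far, and close to it stands compound 1, with structure `CC(=O)Nc1cc(-c2ccc(N(C)C(=O)c3c(F)cccc3Cl)c(N3CCCCC3)c2)n(C(C)C)n1`, which in this assay gives 0.004. Within the data shown here, the only step measured between them, a 1.3-fold lower number from compound 1 to compound 2 (0.12 log units; within the scatter), came with isobutoxy taking the place of piperidin-1-yl on an aromatic carbon, and it stayed within the scatter.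

Compound 3, with structure `CC(=O)Nc1cc(-c2ccc(N(C)C(=O)c3c(F)cccc3Cl)c(N3CCCC3)c2)n(C(C)C)n1`, now carries pyrrolidin-1-yl in place of isobutoxy on an aromatic carbon. This change largely runs the earlier step backwards, since a nitrogen ring again replaces the isobutoxy group; the step from compound 1 to compound 2 was within the scatter, so no step beyond the scatter is expected here either. For compound 3 the expected step is a 1.3-fold higher number from compound 2 to compound 3 (0.12 log units; within the scatter), and its unbound fraction in this assay is estimated at 0.004, within a range from 0.002 to 0.008.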

Compound 3, unbound fraction: 0.017
Beside the measured number, compound 3's estimate is 4.3-fold (0.63 log units) below it; measured number outside the range, above it.
By their numbers in this assay, from the lowest: compounds 2 and 1 (each within the scatter of the next); then compound 3.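

The position on the aromatic carbon is not indifferent to its group, as the earlier pair within the scatter might have suggested: in this assay pyrrolidin-1-yl brings a 5.7-fold higher number from compound 2 to compound 3 (0.75 log units; beyond the scatter) and also a 4.3-fold higher number from compound 1 to compound 3 (0.63 log units; beyond the scatter) as its two steps. A nitrogen ring at this place is not enough for such a rise, since compound 1 also carries one, and the five-membered ring of compound 3 sets it apart from piperidin-1-yl. Isobutoxy and pyrrolidin-1-yl also match in heavy atoms, hydrogen-bond donors and acceptors, so those counts do not separate them, and no measurement here accounts for the rise.

With only one five-membered ring shown, it stays open whether the rise belongs to that ring alone. A morpholin-4-yl ring or an open-chain amine such as dimethylamino at this place could show whether either follows compound 3 or stays with compound 1 and compound 2.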